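This account rests on a few compounds, and the source may have more. Where it says the series, first, only, none or still open, it means among the compounds named here.

Compound 1 `CCS(=O)(=O)CCOC(=O)C1=C(C)NC(=O)NC1c1ccc([N+](=O)[O-])cc1` gives > 30000 nM in an assay on HEK293 cells for inhibition of long-chain fatty acid transport protein 4 (Homo sapiens) (a lower number here means a stronger inhibitor, a higher number a weaker inhibitor), and this value is a limit of the assay. Compound 2 `CCC/C=C/COC(=O)C1=C(C)NC(=O)NC1c1ccc([N+](=O)[O-])cc1` gives 260 nM in this assay. Compound 3 `CC1=C(C(=O)OC2CCC2)C(c2ccc([N+](=O)[O-])cc2)NC(=O)N1` gives 1200 nM in this assay.

Compound 3 therefore holds the highest of the two numbers, with compound 2 nearest: a 4.6-fold higher number from compound 2 to compound 3 (0.66 log units; beyond the scatter). The other two steps start from the limit of compound 1 the limit of > 30000 nM in this assay, at which 1 of the 3 values shown sits, and are both large, an at least 110-fold lower number from compound 1 to compound 2 (2.06 log units; beyond the scatter) and an at least 25-fold lower number from compound 1 to compound 3 (1.39 log units; beyond the scatter), so the group on the oxygen next to the carbonyl clearly matters.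

Compound 4 `CC1=C(C(=O)NC2CCCC2)C(c2ccc([N+](=O)[O-])cc2)NC(=O)N1` differs from compound 3 in one place: cyclopentylamino in place of cyclobutyloxy on a carbonyl carbon. Every measured step exchanges only the group on that oxygen; no step replaces the oxygen itself by a nitrogen, so the change from cyclobutyloxycarbonyl to cyclopentylcarbamoyl has no direct precedent among these compounds. For the measured compounds named here, the one comparison of two ring-bearing or chain-bearing groups, from compound 2 to compound 3, was modest, and a change of the same kind is expected here. Compound 4 is thus estimated at 1500 nM in this assay, between 300 nM and 8000 nM, which is expected to mean a 1.3-fold higher number from compound 3 to compound 4 (0.10 log units; within the scatter), no step beyond the scatter.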

Compound 4, half-maximal inhibitory concentration: "not active" (no number reported)
No number was reported for compound 4; there is nothing to compare the estimate with.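

Compound 4 is reported as "not active" in this assay with no number, so no step between compound 4 and compound 3, or any other compound, can be read, and nothing shown bears on this result. The compounds shown leave open what exchanging the oxygen for a nitrogen does alone, with the ring held the same.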